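Pyridin-2-yl for 4-fluorophenyl on a second core

The source may report more compounds than this note shows. Statements on the series, on what has been measured and on what is new or still open speak of the compounds shown alone.

Four compounds are compared here, all carrying the same tail joined to one of two different cores. Compound 1 `O=c1oc(-c2ccccc2)nn1CCCCN1CCN(c2ccc(F)cc2)CC1` and compound 2 `O=c1oc(-c2ccccc2)nn1CCCCN1CCN(c2ccccn2)CC1` share the core of compound 1, while compound 3 `O=C1CCc2ccccc2N1CCCCN1CCN(c2ccc(F)cc2)CC1` and the not yet measured compound 4 `O=C1CCc2ccccc2N1CCCCN1CCN(c2ccccn2)CC1` share the core of compound 3. The difference between the two cores is not broken down here.

In an assay on cell membranes for displacement of a labelled ligand from Sigma non-opioid intracellular receptor 1 (Cavia porcellus), read by scintillation counting, with a stated time of 120 min (on this read-out lower numbers stand for stronger inhibition and higher numbers for weaker inhibition), compound 1 gives 383 nM and compound 2 gives 944 nM. On the core of compound 3, compound 3 gives 16 nM, the lowest number of the three measured compounds, with compound 1 the nearest of the others and compound 2 the furthest.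

Among the compounds with values here, the one change that is measured on the first core is pyridin-2-yl in place of 4-fluorophenyl on an amine nitrogen in a ring. It produced a 2.5-fold higher number from compound 1 to compound 2 (0.39 log units; beyond the scatter), a modest step, but one that lies beyond the usual scatter. The change from compound 3 to compound 4, (pyridin-2-yl in place of 4-fluorophenyl on an amine nitrogen in a ring), is the same change at the same place, now on the core of compound 3.

Within the data shown here, compound 4 is expected to show a step of a 2.5-fold higher number from compound 3 to compound 4 (0.40 log units; beyond the scatter) in this assay, because a 2.5-fold higher number from compound 1 to compound 2 (0.39 log units; beyond the scatter) is the only measurement of this change and it is taken to carry over to the second core. Among the measured compounds shown here, compound 4 is therefore estimated at 40 nM, with a range from 15 nM to 110 nM to allow for the single precedent and the scatter of the assay.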

Compound 4, inhibition constant: 120 nM
Beside the measured number, compound 4's estimate is 3.0-fold (0.48 log units) below it, outside the stated range (above it).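

In this assay, putting pyridin-2-yl in place of 4-fluorophenyl on the amine nitrogen in a ring also raised the number on the second core, with a 7.5-fold higher number from compound 3 to compound 4 (0.88 log units; beyond the scatter). The direction of the change therefore held on both cores, but its size did not, and the two steps differ: the same change on two cores in this assay, a 2.5-fold higher number (0.39 log units; beyond the scatter) from compound 1 to compound 2 and a 7.5-fold higher number (0.88 log units; beyond the scatter) from compound 3 to compound 4, 3.0-fold (0.48 log units) apart, beyond the scatter of two such steps This shows that, for these two pairs, the step on the first core gave the direction of the step on the second but not a size that could simply be carried across, and it does not show why the size differs or how the change would behave on any further core.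

The compounds shown leave open whether the gap between the two steps follows from the core as a whole or from one part of it, as the difference between the two cores is not broken down into single changes. They also leave open how a plain phenyl group or a pyrimidinyl group on the same ring nitrogen would behave on each core, and whether the two steps would stay apart with a longer chain joining the core to the ring.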